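Adding a methoxy group to the best compound so far

The compounds below may be only part of what the source reports. "The series", "measured", "known", "first", "only" and "open" are said of these compounds alone.

Compound 1 `c1ccc(-c2ccc(-c3ccc(-c4nc5ccccc5[nH]4)cc3)cc2)cc1` gives 39200 nM
Compound 2 `COc1cc(-c2ccc(-c3ccc(-c4nc5ccccc5[nH]4)cc3)cc2)cc(OC)c1OC` gives 6380 nM
Compound 3 `Oc1cccc2[nH]c(-c3ccc(-c4ccc(-c5ccccc5)cc4)cc3)nc12` gives 2200 nM

These numbers come from a functional assay on MCF7 cells (Homo sapiens) for inhibition, read by sulforhodamine B assay (on this read-out higher numbers stand for weaker inhibition of growth and lower numbers for stronger inhibition of growth), and compound 3 has the lowest of the three, with a clear gap to compound 2, its nearest neighbour. Compound 4 `COc1ccc(-c2ccc(-c3ccc(-c4nc5c(O)cccc5[nH]4)cc3)cc2)cc1` differs from compound 3 by one change methoxy in place of hydrogen on an aromatic carbon which can be read as phenyl to 4-methoxyphenyl.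

Among the compounds with values here, only one measured step involves a single change, and it is an 18-fold lower number from compound 1 to compound 3 (1.25 log units; beyond the scatter) for hydroxy in place of hydrogen. That is a large step, but compound 4 keeps this hydroxy group, so the step shows only how far one small group can move the number here, not what methoxy will do. A closer hint comes from compound 1 and compound 2, which carries methoxy groups and has no hydroxy: compound 1 reads 39200 nM and compound 2 reads 6380 nM on this scale. That pair differs in more than one place, and compound 4 gains only one methoxy, so the hint is loose. A small move towards a lower number is therefore expected, namely a 1.8-fold lower number from compound 3 to compound 4 (0.26 log units; within the scatter) in this assay as an estimate. For compound 4 the estimated value is 1200 nM (expected range 350 nM to 4000 nM).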

Compound 4, concentration for 50% growth inhibition: 3110 nM
Estimate against measurement, compound 4: 2.6-fold (0.41 log units) below; low and high end bracket the measured number.
By their numbers in this assay, from the lowest: compounds 3 and 4 (each within the scatter of the next); then compound 2; then compound 1.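

In this assay, methoxy in place of hydrogen on an aromatic carbon, para to a large group, gives a 1.4-fold higher number from compound 3 to compound 4 (0.15 log units; within the scatter) and so leaves compound 3 and compound 4 within the usual scatter of each other. This is the first single change shown on this ring, and it shows that, with the hydroxy group in place, phenyl to 4-methoxyphenyl has no effect that this read-out can separate from scatter. Within the data shown here, the only earlier single change, hydroxy in place of hydrogen, behaved quite differently and gave an 18-fold lower number from compound 1 to compound 3 (1.25 log units; beyond the scatter) on another part of the molecule, so a small group can matter greatly in one place and not measurably in another. No measurement shown here offers an explanation for this contrast.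

Still open, on these data alone, is whether an amine, a carboxylic acid or a longer chain such as butoxy in this same place would also stay within the scatter of compound 3 or would move the number clearly. Among these compounds, it is also open whether the single methoxy group would read the same way on the core of compound 1, which lacks the hydroxy group.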